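The compounds below may be only part of what the source reports. "The series", "measured", "known", "first", "only" and "open" are said of these compounds alone.

In a functional assay on CCRF-CEM cells (Homo sapiens) for inhibition, read by MTT assay, with a stated time of 72 h (on this read-out lower numbers stand for stronger inhibition and higher numbers for weaker inhibition), compound 1 `COc1cc(NC(C)CCCNC(=O)NNC(=O)Nc2ccc(C(F)(F)F)cc2)c2ncccc2c1` gives 18000 nM, compound 3 `COc1cc(NC(C)CCCNC(=O)Nc2cc(C(F)(F)F)cc(C(F)(F)F)c2)c2ncccc2c1` gives 4100 nM and compound 2 `COc1cc(NC(C)CCCNC(=O)NNC(=O)Nc2ccc(Br)cc2)c2ncccc2c1` gives 110000 nM, the highest and so the weakest of the three. Compound 4 `COc1cc(NC(C)CCCNC(=O)Nc2ccc(O)cc2)c2ncccc2c1` carries 4-hydroxyphenyl in place of ((4-bromophenyl)carbamoyl)amino on an amide-type nitrogen. Among the compounds with values here, no measured step covers this exchange. The closest guide is a 6.1-fold higher number from compound 1 to compound 2 (0.79 log units; beyond the scatter), a smaller swap that still moved the number beyond the scatter. Compound 3 also lacks the carbamoyl amino unit and stands at 4100 nM, so a moderately lower number is expected in this assay. The expected change is a 3.7-fold lower number from compound 2 to compound 4 (0.56 log units; beyond the scatter). For compound 4 the estimated value is 30000 nM, within an expected range of 8000 nM to 100000 nM.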

Compound 4, half-maximal inhibitory concentration: 23000 nM
Estimate against measurement, compound 4: 1.3-fold (0.12 log units) above, within the range that was stated.
By their numbers in this assay, from the lowest: compound 3; then compounds 1 and 4 (each within the scatter of the next); then compound 2.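

In this assay, within the data shown here, the earlier step swapped only one group on an aromatic ring, whereas here the whole unit on the amide-type nitrogen is exchanged, giving a 4.8-fold lower number from compound 2 to compound 4 (0.68 log units; beyond the scatter). This shows that the position accepts the smaller 4-hydroxyphenyl in place of ((4-bromophenyl)carbamoyl)amino with a gain, though the carbamoyl amino part and the bromo group leave together. No measured information explains this change. Going by these compounds, how much of the step belongs to each departing part stays open, as does whether an amine or a carboxylic acid in place of the hydroxy group would move the number further.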